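Swapping a fluoro for an allyloxy on the chalcone ring

The source may hold more compounds than are shown below. What is called first, only, known or untested is meant among the compounds shown, and "the series" means these compounds.

Measured compounds:
compound 1 `Cc1ccc(S(=O)(=O)NC(=O)Nc2ccccc2C(=O)/C=C/c2cc(O)ccc2[N+](=O)[O-])cc1` gives 18.3 ug/mL in an ADME assay on the whole organism for cytotoxicity, with Artemia salina as the target, with a stated time of 24 h; a lower number here means that less compound is needed, a higher number that more compound is needed for the effect
compound 2 `Cc1ccc(S(=O)(=O)NC(=O)Nc2ccccc2C(=O)/C=C/c2ccc(F)cc2)cc1` gives 3.96 ug/mL in this assay

Compound 2 holds the lowest number of the two in this assay; the nearest is compound 1, and the step of a 4.6-fold lower number from compound 1 to compound 2 (0.66 log units; beyond the scatter) lies beyond the scatter. Compound 3 `C=CCOc1ccc(/C=C/C(=O)c2ccccc2NC(=O)NS(=O)(=O)c2ccc(C)cc2)cc1` has not yet been tested in this assay. It differs from compound 2 in one place: allyloxy in place of fluoro on an aromatic carbon. Going by the values given here, only one measured step bears on this change, namely a 4.6-fold lower number from compound 1 to compound 2 (0.66 log units; beyond the scatter), which shows that the groups on this aromatic ring, para to a large group, shift the number noticeably. Among the compounds with values here, no measured pair shows an allyloxy on that ring, so the direction of the new step is open. Compound 3 is therefore expected to give about 6 ug/mL in this assay, with a range from 2.5 ug/mL to 15 ug/mL. This estimate means a step of a 1.5-fold higher number from compound 2 to compound 3 (0.18 log units; within the scatter), expected to stay close to the scatter.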

Compound 3, concentration for half-maximal effect: 6.11 ug/mL
Beside the measured number, compound 3's estimate is 1.0-fold (0.01 log units) below it; measured number inside the range.
By their numbers in this assay, from the lowest: compounds 2 and 3 (each within the scatter of the next); then compound 1.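

The result shows that this place, para to a large group, accepts allyloxy with its 4 heavy atoms in place of the single fluorine atom without the reading in this assay leaving the scatter: a 1.5-fold higher number from compound 2 to compound 3 (0.19 log units; within the scatter). The second step, a 3.0-fold lower number from compound 1 to compound 3 (0.48 log units; beyond the scatter), shows that 4-(allyloxy)phenyl, like 4-fluorophenyl, gives a clearly lower number than 5-hydroxy-2-nitrophenyl, so this gap no longer rests on a single group. No supporting measurement is available to explain why fluoro and allyloxy give such similar readings.

The compounds shown leave open whether the number stays in this range with an amine, a carboxylic acid or a longer chain at this place. They also do not separate the hydroxy from the nitro in the ring of compound 1.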